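Notes on the amine substituent, compound 2 to compound 4

The source may report more compounds than this note shows. Statements on the series, on what has been measured and on what is new or still open speak of the compounds shown alone.

The shared core carries a variable group on a saturated chain carbon bound to an aromatic carbon. Compound 1 `COc1ccc(/C=C\c2cc(OC)c(OC)c(OC)c2)cc1OCc1ccc(CN2CCCC[C@@H]2C(=O)O)cc1` bears 2-carboxypiperidin-1-yl there; in a functional assay on B16-F10 cells (Mus musculus) for antiproliferative activity, read by CCK-8 assay, with a stated time of 48 h (on this read-out higher numbers stand for weaker inhibition and lower numbers for stronger inhibition), compound 1 gives only a limit, > 10000 nM. Compound 2 `COc1ccc(/C=C\c2cc(OC)c(OC)c(OC)c2)cc1OCc1ccc(CNCCO)cc1` bears (2-hydroxyethyl)amino, and in this assay compound 2 gives 6600 nM, the highest of the two numbers shown. Compound 3 `COc1ccc(/C=C\c2cc(OC)c(OC)c(OC)c2)cc1OCc1ccc(CN2CCCCC2C(=O)NCCN)cc1` bears 2-((2-aminoethyl)carbamoyl)piperidin-1-yl and gives 4600 nM; the step of a 1.4-fold lower number from compound 2 to compound 3 (0.16 log units; within the scatter) lies within the scatter. Compound 4 `COc1ccc(/C=C\c2cc(OC)c(OC)c(OC)c2)cc1OCc1ccc(CN[C@H](C(=O)O)[C@@H](C)O)cc1` differs from compound 2 by 1-carboxy-2-hydroxypropyl in place of 2-hydroxyethyl on an amine nitrogen. The change brings a carboxy group onto the amine, as compound 1 carries one, and the steps of an at least 1.5-fold lower number from compound 1 to compound 2 (0.18 log units; that floor lies within the scatter) and an at least 2.1-fold lower number from compound 1 to compound 3 (0.33 log units; beyond the scatter) both run away from that carboxy-bearing group. The step from compound 2 to compound 4 is therefore expected to run the other way, toward a higher number, with the limit of > 10000 nM in this assay, at which 1 of the 3 values shown sits, meaning the result may again be only a limit. The estimate for compound 4 is 11000 nM, range 4000 nM to 30000 nM, an expected step of a 1.7-fold higher number from compound 2 to compound 4 (0.22 log units; within the scatter).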

Compound 4, half-maximal inhibitory concentration: 5400 nM
Beside the measured number, compound 4's estimate is 2.0-fold (0.31 log units) above it; measured number inside the range.
By their numbers in this assay, from the lowest: compounds 3, 4 and 2 (each within the scatter of the next). At a limit, above all of these: compound 1.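

In this assay, 1-carboxy-2-hydroxypropyl in place of 2-hydroxyethyl on an amine nitrogen gives a 1.2-fold lower number from compound 2 to compound 4 (0.09 log units; within the scatter), and (1-carboxy-2-hydroxypropyl)amino in place of 2-((2-aminoethyl)carbamoyl)piperidin-1-yl gives a 1.2-fold higher number from compound 3 to compound 4 (0.07 log units; within the scatter), so these substituents cannot be told apart at this position. A carboxy group on the amine does not by itself put a compound at the limit: compound 4 carries one and gives a measured number. The step that starts from a limit reads an at least 1.8-fold lower number from compound 1 to compound 4 (0.26 log units; that floor lies within the scatter), a floor only: the limit of > 10000 nM in this assay, at which 1 of the 4 values shown sits.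

As far as these compounds go, it remains open whether the carboxy group and the hydroxyl of the new substituent each matter, which a carboxymethyl group on the same amine nitrogen would help to separate. Also open, from the compounds shown here alone, is whether a primary amine or a longer hydroxyalkyl chain at this position would give a number beyond the scatter of compound 2, compound 3 and compound 4.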